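Changing the aryl sulfide on a shared core

The source may report more compounds than this note shows. Statements on the series, on what has been measured and on what is new or still open speak of the compounds shown alone.

Measured compounds in a functional assay on IGROV-1 cells (Homo sapiens) for inhibition, read by sulforhodamine B assay, with a stated time of 48 h; a higher number here means a weaker inhibitor of growth, a lower number a stronger inhibitor of growth:
Compound 1, `Nc1cc(N)c2nc(-c3ccccc3)c(Oc3ccc(Cl)c(Cl)c3)nc2c1`: 32400 nM
Compound 3, `Nc1cc(N)c2nc(-c3ccccc3)c(Sc3ccc(Cl)c(Cl)c3)nc2c1`: 27500 nM
Compound 2, `Nc1cc(N)c2nc(-c3ccccc3)c(NCc3ccc(F)cc3)nc2c1`, sits at the limit of this assay, giving < 100000 nM.

Compound 3 holds the lowest of the two readable numbers in this assay, with compound 1 nearest; the step of a 1.2-fold lower number from compound 1 to compound 3 (0.07 log units; within the scatter) lies within the scatter. The step that the limit leaves unreadable from compound 1 to compound 2 is left unreadable by the limit (the limit of < 100000 nM in this assay, at which 1 of the 3 values shown sits), and the same holds for a step that the limit leaves unreadable from compound 2 to compound 3.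

Compound 4, `Nc1cc(N)c2nc(-c3ccccc3)c(Sc3ccc(F)cc3)nc2c1`, differs from compound 3 only by 4-fluorophenyl in place of 3,4-dichlorophenyl on a sulfur. Among the compounds with values here, no measured step touches this change directly: the one readable step, from compound 1 to compound 3, alters the atom joining the aryl group to the core, not the aryl group itself, and the only compound carrying a 4-fluorophenyl fragment, compound 2, sits at the limit. The expectation for compound 4 in this assay therefore rests on little, and a somewhat higher number than compound 3 shows is guessed, with a wide range. Compound 4 is estimated at 45000 nM, between 15000 nM and 100000 nM. This estimate corresponds to an expected step of a 1.6-fold higher number from compound 3 to compound 4 (0.21 log units; within the scatter).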

Compound 4, concentration for total growth inhibition: < 100000 nM
Compound 4: a limit, no number; the forecaster's own chance of this, stated with the estimate: 35%; the middle value is on the limit's open side.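

In this assay compound 4 gives < 100000 nM as a limit and not a number. Its steps from compound 1, compound 2 and compound 3 therefore cannot be read: the limit of < 100000 nM in this assay, at which 2 of the 4 values shown sit.

The compounds shown leave open whether 4-fluorophenyl in place of 3,4-dichlorophenyl on a sulfur changes growth inhibition at all, and in which direction.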